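Swapping one sulfonyl aryl for chlorothiophene in a bis-sulfonamide

The compounds below may be only part of what the source reports. "The series", "measured", "known", "first", "only" and "open" are said of these compounds alone.

Three compounds share a core carrying two sulfonamide arms, and they differ only in the aromatic groups on the sulfonyl sulfurs. Compound 1 `O=S(=O)(Nc1ccc2oc(-c3ccc(NS(=O)(=O)c4ccc(Cl)s4)cc3)nc2c1)c1ccc(Cl)c(Cl)c1` gives 4700 nM in an assay for inhibition of HSP60/HSP10 (Homo sapiens), with a stated time of 60 min (on this read-out higher numbers stand for weaker inhibition and lower numbers for stronger inhibition), the lowest of the three numbers. Compound 3 `O=S(=O)(Nc1ccc2oc(-c3ccc(NS(=O)(=O)c4ccc(Cl)s4)cc3)nc2c1)c1cccc(C(F)(F)F)c1` gives 5000 nM, and compound 2 `O=S(=O)(Nc1ccc(-c2nc3cc(NS(=O)(=O)c4cccc(C(F)(F)F)c4)ccc3o2)cc1)c1cccc(C(F)(F)F)c1` gives 58000 nM. The step of a 1.1-fold higher number from compound 1 to compound 3 (0.03 log units; within the scatter) shows that trading 3,4-dichlorophenyl for 3-(trifluoromethyl)phenyl changes little, while the step of a 12-fold lower number from compound 2 to compound 3 (1.06 log units; beyond the scatter) shows that bringing in 5-chlorothiophen-2-yl on one sulfonyl sulfur lowers the number strongly.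

Compound 4 `O=S(=O)(Nc1ccc(-c2nc3cc(NS(=O)(=O)c4ccc(Cl)s4)ccc3o2)cc1)c1ccc(Cl)s1` arises from compound 1 through (5-chlorothiophen-2-yl in place of 3,4-dichlorophenyl on a sulfonyl sulfur), so that both sulfonyl sulfurs now carry 5-chlorothiophen-2-yl. Because the first such exchange gave a 12-fold lower number from compound 2 to compound 3 (1.06 log units; beyond the scatter), and because the group leaving here behaved like trifluoromethylphenyl in a 1.1-fold higher number from compound 1 to compound 3 (0.03 log units; within the scatter), a lower number is expected for compound 4, of the size a 3.9-fold lower number from compound 1 to compound 4 (0.59 log units; beyond the scatter). Compound 4 is estimated at 1200 nM in this assay, within a range from 400 nM to 4000 nM.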

Compound 4, half-maximal inhibitory concentration: 5900 nM
For compound 4 the middle estimate is 4.9-fold (0.69 log units) below the measured one; measured number above the stated range.
By their numbers in this assay, from the lowest: compounds 1, 3 and 4 (each within the scatter of the next); then compound 2.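

With 5-chlorothiophen-2-yl already on one sulfonyl sulfur, placing the same group on the second sulfonyl sulfur leaves the number within the scatter, whether it enters in place of 3,4-dichlorophenyl (a 1.3-fold higher number from compound 1 to compound 4 (0.10 log units; within the scatter)) or in place of 3-(trifluoromethyl)phenyl (a 1.2-fold higher number from compound 3 to compound 4 (0.07 log units; within the scatter)). The large drop from the first exchange (a 12-fold lower number from compound 2 to compound 3 (1.06 log units; beyond the scatter)) therefore does not repeat with the second, so a second 5-chlorothiophen-2-yl brings no further measurable gain in these compounds. No measurement given here accounts for this difference between the two exchanges.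

Still open, as far as these compounds go, is whether any group on this second sulfonyl sulfur can lower the number beyond the scatter. A phenyl ring carrying an amine or a carboxylic acid, or a plain alkyl chain in place of the aromatic ring, could answer that.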